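A few compounds are considered here, and "the series" means these few. Any claim that something is new, unique, unknown or untested is made for them only; others in the source may bear on it.

Measured compounds in a functional assay on HCT-116 cells (Homo sapiens) for antiproliferative activity, read by MTT assay, with a stated time of 72 h; on this read-out higher numbers stand for weaker inhibition and lower numbers for stronger inhibition:

- compound 1, `CC(C)c1cccc(NC(=O)CCc2cccc3c2B(O)OC3)c1`: 1600 nM
- compound 2, `O=C(CCc1cccc2c1B(O)OC2)Nc1ccc2ccccc2c1`: 1700 nM

Both measured compounds share the same core, a cyclic boronic ester joined through a short chain to an amide, and differ only in the group carried on the amide nitrogen. Compound 1 carries an isopropyl group on its aromatic ring, compound 2 a fused two-ring aromatic system. In this assay compound 1 gives 1600 nM and compound 2 gives 1700 nM; the two numbers sit within the usual scatter of each other, so neither compound can be said to stand apart from the other.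

Compound 3, `N#Cc1ccc(-c2cccc(NC(=O)CCc3cccc4c3B(O)OC4)c2)cc1`, is not yet measured. It keeps the core of compound 1 and changes one place: 4-cyanophenyl in place of isopropyl on an aromatic carbon. The two measured compounds show that exchanging a small group for a larger aromatic one on this part of the molecule left the number essentially where it was, and no step beyond the scatter has been observed in this series. The expected step is therefore small: a 1.1-fold lower number from compound 1 to compound 3 (0.03 log units; within the scatter), in no clear direction. Compound 3 is estimated at 1500 nM, with a range from 500 nM to 4500 nM.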

Compound 3, half-maximal inhibitory concentration: 410 nM
Beside the measured number, compound 3's estimate is 3.7-fold (0.56 log units) above it, and the stated range ends above it.
By their numbers in this assay, from the lowest: compound 3; then compounds 1 and 2 (each within the scatter of the next).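

In this assay, putting 4-cyanophenyl in place of isopropyl on this aromatic carbon gives a 3.9-fold lower number from compound 1 to compound 3 (0.59 log units; beyond the scatter) and is the only step shown that lies beyond the scatter. The step is modest, but it shows that this position is not indifferent to what it carries: the larger group, with its aromatic ring and nitrile, goes with stronger inhibition rather than weaker, on a read-out where a lower number means stronger inhibition.

This single change brings in the ring and the nitrile together, so the compounds shown cannot separate them, and a plain phenyl group would be needed to tell how much of the step remains without the nitrile. On these data alone, it also remains open how the number would respond if a carboxylic acid or an amine stood in place of the nitrile on that ring. No measurement shown here explains why the number falls with this change.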